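The compounds below may be only part of what the source reports. "The series", "measured", "known", "first", "only" and "open" are said of these compounds alone.

Compounds measured in a functional assay for activation of Alpha-1B adrenergic receptor (Homo sapiens), read by calcium flux; on this read-out lower numbers stand for an effect already at smaller amounts and higher numbers for an effect only at larger amounts of compound:

- compound 1, `CCN(CC)C(=O)c1ccccc1OCC1=NCCN1` — < 5020 nM
- compound 2, `Cc1cccnc1-c1ccccc1OCC1=NCCN1` — < 100000 nM
- compound 3, `c1c[nH]c(-c2ccccc2OCC2=NCCN2)c1` — 1 nM

All three share the same core, an aromatic ring carrying a cyclic amidine side chain, and differ in the group on the neighbouring aromatic carbon. For compound 1 the entry is a limit of this assay, not a number (the limit of < 5020 nM in this assay, at which 1 of the 3 values shown sits). For compound 2 the entry is also a limit (the limit of < 100000 nM in this assay, at which 1 of the 3 values shown sits). Among the measured compounds shown here, compound 3 is therefore the only one with a true number, and its value 1 nM stands as the single fixed point among the three.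

Compound 4, `Cc1csc(-c2ccccc2OCC2=NCCN2)n1`, is the next step from compound 3. The change is 4-methyl-1,3-thiazol-2-yl in place of 1H-pyrrol-2-yl on an aromatic carbon. For the measured compounds named here, with no measured pair differing in one place, the size of this step is unknown; the shift from a group with a hydrogen-bond donor to one without is expected to cost activity, so the step from compound 3 to compound 4 is estimated as a 50-fold higher number from compound 3 to compound 4 (1.70 log units; beyond the scatter). Compound 4 is expected to give about 50 nM, within 5 nM to 1000 nM.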

Compound 4, half-maximal effective concentration: < 100000 nM
Compound 4: only a limit was reported; the forecaster's own chance of this, stated with the estimate: 15%; the middle value lies beyond the limit too.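

Compound 4 gives < 100000 nM, which is a limit and not a number, so no step can be read from compound 3 to compound 4. The compounds shown leave open how large that step is, and which difference between 1H-pyrrol-2-yl and 4-methyl-1,3-thiazol-2-yl matters for activation.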